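Chloro for Fluoro: A Halogen Swap With Little Guidance

A few compounds are considered here, and "the series" means these few. Any claim that something is new, unique, unknown or untested is made for them only; others in the source may bear on it.

Among the measured compounds shown here, compound 1 `COc1cc(-c2nc(-c3ccccc3)[nH]c2-c2ccnc(NCCCNS(=O)(=O)c3ccc(Cl)cc3)n2)ccc1F` is one of two compounds measured in a functional assay on LOX IMVI cells (Homo sapiens) for cytotoxicity, read by MTT assay, with a stated time of 24 h; on this read-out lower numbers stand for stronger inhibition and higher numbers for weaker inhibition. In this assay compound 1 gives 83100 nM, the higher of the two numbers. For the measured compounds named here, compound 2 `COc1cc(-c2nc(-c3ccccc3)[nH]c2-c2ccnc(NCCCNS(=O)(=O)c3cccc4ccccc34)n2)ccc1F` carries naphthalen-1-yl in place of 4-chlorophenyl on the sulfonyl sulfur, and compound 2 gives 14900 nM; the step between them is a 5.6-fold lower number from compound 1 to compound 2 (0.75 log units; beyond the scatter), the only measured comparison in this set. Compound 3 `COc1cc(-c2nc(-c3ccccc3)[nH]c2-c2ccnc(NCCCNS(=O)(=O)c3ccc(Cl)cc3)n2)ccc1Cl` differs from compound 1 in a different part of the molecule: chloro in place of fluoro on an aromatic carbon. Going by the values given here, no measured step touches this position, so the single measured comparison, a 5.6-fold lower number from compound 1 to compound 2 (0.75 log units; beyond the scatter), gives no direct guidance on it. With one atom leaving and one entering and nothing measured to weigh it, the expectation is a change no larger than the usual scatter, a 1.0-fold lower number from compound 1 to compound 3 (0.02 log units; within the scatter). Compound 3 is therefore estimated at 80000 nM, with a range from 30000 nM to 200000 nM.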

Compound 3, half-maximal inhibitory concentration: 60900 nM
Estimate against measurement, compound 3: 1.3-fold (0.12 log units) above; the range from low to high includes it.
By their numbers in this assay, from the lowest: compound 2; then compounds 3 and 1 (each within the scatter of the next).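

Putting chloro in place of fluoro on the aromatic carbon ortho to the methoxy group gives a 1.4-fold lower number from compound 1 to compound 3 (0.13 log units; within the scatter) in this assay and, at that size, the two compounds cannot be told apart. At this position, one halogen can therefore take the place of the other with no clear shift in the number, unlike the change on the sulfonyl sulfur, which gave a 5.6-fold lower number from compound 1 to compound 2 (0.75 log units; beyond the scatter) and lies beyond the scatter. Nothing available explains why the two halogens read alike.

The compounds shown leave open what an amine or a carboxylic acid at this position would do to the number. They also leave open whether the same halogen swap would read alike in compound 2, which carries naphthalen-1-yl on the sulfonyl sulfur.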